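Second methoxy on the styryl ring: compound 3 to compound 4

The compounds below may be only part of what the source reports. "The series", "measured", "known", "first", "only" and "open" are said of these compounds alone.

Measured so far:
compound 1 `O=C1C=COC(/C=C/c2ccccc2)C1`, 153 uM
compound 2 `O=C1C=COC(/C=C/c2ccc(C(F)(F)F)cc2)C1`, 41.2 uM
compound 3 `COc1ccc(/C=C/C2CC(=O)C=CO2)cc1`, 156 uM

All three share one core and differ only in the group on the aromatic ring. In a functional assay on MCF7 cells (Homo sapiens) for inhibition, read by sulforhodamine B assay, with a stated time of 48 h (on this read-out higher numbers stand for weaker inhibition of growth and lower numbers for stronger inhibition of growth), compound 1 gives 153 uM and compound 3 gives 156 uM; the two numbers sit together, as a 1.0-fold higher number from compound 1 to compound 3 (0.01 log units; within the scatter) shows. Compound 2 stands apart: a 3.7-fold lower number from compound 1 to compound 2 (0.57 log units; beyond the scatter) and a 3.8-fold higher number from compound 2 to compound 3 (0.58 log units; beyond the scatter) are both beyond the scatter, so compound 3 sits at the upper end of the set, together with compound 1 and separated from compound 2.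

Compound 4 `COc1ccc(/C=C/C2CC(=O)C=CO2)cc1OC` is not yet measured. It differs from compound 3 by methoxy in place of hydrogen on an aromatic carbon. Among the compounds with values here, the one measured step of the same kind, methoxy in place of hydrogen on an aromatic carbon, is a 1.0-fold higher number from compound 1 to compound 3 (0.01 log units; within the scatter), which stayed within the scatter. The two steps involving trifluoromethyl do not bear on a methoxy entering. On this basis a second methoxy is expected to leave the number about where compound 3 stands, with at most a small movement in either direction and none beyond the scatter.

The estimate for compound 4 in this assay is therefore 135 uM, within 60 uM to 300 uM, an expected step of a 1.2-fold lower number from compound 3 to compound 4 (0.06 log units; within the scatter).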

Compound 4, concentration for growth inhibition (reported as GI): 130 uM
Compound 4: middle estimate off by 1.0-fold (0.02 log units), on the high side, within the range that was stated.
By their numbers in this assay, from the lowest: compound 2; then compounds 4, 1 and 3 (each within the scatter of the next).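

In this assay, a methoxy placed ortho to a methoxy group and meta to a group of 9 heavy atoms gives a 1.2-fold lower number from compound 3 to compound 4 (0.08 log units; within the scatter), so a second methoxy on the ring stays within the scatter, as the first did in a 1.0-fold higher number from compound 1 to compound 3 (0.01 log units; within the scatter). Both methoxy steps in the series therefore leave the number within the scatter, and neither goes against this. This now covers a ring carbon ortho to a methoxy group as well as the site taken by the first methoxy, while the clear movement remains the trifluoromethyl step, a 3.7-fold lower number from compound 1 to compound 2 (0.57 log units; beyond the scatter). No measurement shown here offers an explanation for the flat methoxy steps.

The compounds shown leave open whether this position is insensitive to substitution in general or only to methoxy, as they include no amine, hydroxyl or carboxylic acid there, nor a longer alkoxy chain. They also leave open whether trifluoromethyl at this position, ortho to a methoxy group, would move the number as it does in the step to compound 2.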